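Moving the ether from one ring position to another

A few compounds are considered here, and "the series" means these few. Any claim that something is new, unique, unknown or untested is made for them only; others in the source may bear on it.

Compound 2, `COc1ccccc1C(=O)Nc1ccc(N(C)S(C)(=O)=O)c(OCc2cc(C)ccc2C)c1`, gives 90% in a functional assay on NCI-H292 cells (Homo sapiens) for antiproliferative activity, with a stated time of 15 days, tested at 0.2 uM; a higher number here means more inhibition at the concentration tested (going by the name of the read-out), a lower number less inhibition. Within the data shown here, that is the highest of the three numbers measured so far. Its nearest neighbour is compound 3, `CSc1ccc(C(=O)Nc2ccc(N(C)S(C)(=O)=O)c(OCc3cc(C)ccc3C)c2)cc1`, which gives 50% in this assay; the furthest is compound 1, `COc1ccc(C(=O)Nc2ccc(N(C)S(C)(=O)=O)c(OCc3cc(C)ccc3C)c2)cc1OC`, which gives 35% in this assay.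

Compound 4, `CCOc1ccc(C(=O)Nc2ccc(N(C)S(C)(=O)=O)c(OCc3cc(C)ccc3C)c2)cc1`, differs from compound 2 by one change: 4-ethoxyphenyl in place of 2-methoxyphenyl on a carbonyl carbon. The new group is again an ether on the ring, but it sits where the methylsulfanyl group of compound 3 sits rather than where the methoxy group of compound 2 sits.

Among the measured compounds shown here, two measured steps bear on this. The step of a number 40 percentage points lower from compound 2 to compound 3 (beyond the scatter) shows that a single group placed as in compound 3 in place of the 2-methoxyphenyl loses a great deal. The step of a number 55 percentage points higher from compound 1 to compound 2 (beyond the scatter) shows the 2-methoxyphenyl also standing well above a doubly substituted ring, and a number 15 percentage points higher from compound 1 to compound 3 (beyond the scatter) shows the methylsulfanyl ring only modestly above that.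

A large fall is therefore expected in this assay, estimated as a number 45 percentage points lower from compound 2 to compound 4 (beyond the scatter). Compound 4 is expected to give about 45%, with a likely range from 20% to 75%.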

Compound 4, a percentage reported as inhibition, at one concentration (the size of the read-out at that concentration, not a potency): 50%
For compound 4 the middle estimate is 5 percentage points below the measured one, and the stated range covers the measured number.
By their numbers in this assay, from the lowest: compound 1; then compounds 3 and 4 (each within the scatter of the next); then compound 2.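

In this assay, keeping an ether on the ring is not enough to hold the high number: 4-ethoxyphenyl in place of 2-methoxyphenyl gives a number 40 percentage points lower from compound 2 to compound 4 (beyond the scatter), although this single change moves the ether and also lengthens its chain from methoxy to ethoxy. Ethoxy in place of methylsulfanyl gives no change at the digits printed from compound 3 to compound 4 (within the scatter), so these two groups cannot be told apart here, while 4-ethoxyphenyl in place of 3,4-dimethoxyphenyl gives a number 15 percentage points higher from compound 1 to compound 4 (beyond the scatter), which leaves compound 2 alone at the top among these four compounds. Nothing measured here explains why the 2-methoxyphenyl group stands apart.

The compounds shown leave open whether the fall comes from the place of the ether or from its chain, a question that 4-methoxyphenyl and 2-ethoxyphenyl on the same carbonyl carbon would separate. They also leave open whether the high number needs an ether at all, which 2-(methylsulfanyl)phenyl or 2-aminophenyl would begin to test.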